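Thiazolylhydrazones: cyano for methyl on the pendant phenyl

The source may report more compounds than this note shows. Statements on the series, on what has been measured and on what is new or still open speak of the compounds shown alone.

Compound 1 `C(=N/Nc1nc(-c2ccccc2)cs1)\c1ccc(N2CCCC2)cc1` is the unsubstituted phenyl member of the series. In an assay on isolated protein for inhibition of Amine oxidase [flavin-containing] B (Homo sapiens), read by fluorescence and Amplex Red, with a stated time of 30 min (on this read-out lower numbers stand for stronger inhibition and higher numbers for weaker inhibition), compound 1 gives > 1000000 nM, which is a limit of the assay rather than a number. Compound 2 `Cc1ccc(-c2csc(N/N=C/c3ccc(N4CCCC4)cc3)n2)cc1` carries a methyl on the aromatic carbon instead. In this assay compound 2 gives > 100000 nM, again a limit and not a measured value. The step from compound 1 to compound 2 is therefore a step that the two limits leave unreadable from compound 1 to compound 2, and the two limits the limit of > 1000000 nM in this assay, at which 1 of the 2 values shown sits, and the limit of > 100000 nM in this assay, at which 1 of the 2 values shown sits, leave its size and direction unreadable.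

Compound 3 `N#Cc1ccc(-c2csc(N/N=C/c3ccc(N4CCCC4)cc3)n2)cc1` differs from compound 2 by cyano in place of methyl on an aromatic carbon. Among the compounds with values here, only the one unreadable step bears on this change, so the measured data give no direction for the effect of cyano in place of methyl here. Both neighbours sit at limits; the working expectation is that compound 3 also remains at or near a limit in this assay, with a step from compound 2 to compound 3 estimated at a step that the limit leaves unreadable from compound 2 to compound 3. Compound 3 is thus estimated at 300000 nM, in a range from 30000 nM to 3000000 nM.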

Compound 3, half-maximal inhibitory concentration: 53100 nM
Compound 3: the middle estimate sits 5.6-fold (0.75 log units) above what was measured; measured number inside the range.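

Only with the 4-cyanophenyl does this position, para to a large group, give a measured number in this assay, and cyano in place of methyl reads as an at least 1.8-fold lower number from compound 2 to compound 3 (0.27 log units; that floor lies within the scatter). Cyano in place of hydrogen reads as an at least 18-fold lower number from compound 1 to compound 3 (1.27 log units; beyond the scatter), so substitution at this position can change the read-out, and this floor rests on the limit of compound 1: the limit of > 1000000 nM in this assay, at which 1 of the 3 values shown sits. The floor for cyano in place of methyl rests on the limit of compound 2: the limit of > 100000 nM in this assay, at which 1 of the 3 values shown sits.

On these data alone, the step from compound 1 to compound 2 cannot be read, so the effect of methyl alone at this position stays open, as does the true size of both steps involving cyano. Also open, as far as these compounds go, is whether the change in number is particular to cyano, which a methoxy, an amine or a carboxylic acid at the same position would help to settle.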